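The source may report more compounds than this note shows. Statements on the series, on what has been measured and on what is new or still open speak of the compounds shown alone.

Compound 1, with the structure `CCCCCCCCCCC(CCO)n1cnc2c(N)ncnc21`, carries an unbranched saturated chain and an amino group on its fused two-ring core. In a functional assay on SW480 cells (Homo sapiens) for antiproliferative activity, read by MTT assay, with a stated time of 48 h (a higher number here means a weaker inhibitor, a lower number a stronger inhibitor), compound 1 gives 1200 nM. Compound 2, with the structure `CCCCCCCCCCC(CCO)n1cnc2c(N)nc(Cl)nc21`, differs from compound 1 by chloro in place of hydrogen on an aromatic carbon, placed on an aromatic carbon of a six-membered aromatic ring with 2 nitrogen, between two ring nitrogen atoms. In this assay compound 2 gives 13100 nM, so the change brought an 11-fold higher number from compound 1 to compound 2 (1.04 log units; beyond the scatter). Compound 3, with the structure `CCCCCCCCCCCC(CCO)n1cnc2c(N)ncnc21`, differs from compound 1 instead by methyl in place of hydrogen on a saturated chain carbon, ten or more bonds along the chain from an aromatic nitrogen. In this assay compound 3 gives 11600 nM, and that change brought a 9.7-fold higher number from compound 1 to compound 3 (0.99 log units; beyond the scatter). The values of compound 2 and compound 3 lie within the usual scatter of each other.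

Compound 4, with the structure `CCCCCCCCCCCC(CCO)n1cnc2c(N)nc(Cl)nc21`, has not yet been measured. It differs from compound 3 by chloro in place of hydrogen on an aromatic carbon, the same change, at the same place, that turned compound 1 into compound 2. Because that earlier change gave an 11-fold higher number from compound 1 to compound 2 (1.04 log units; beyond the scatter), the step from compound 3 to compound 4 is expected to be a 4.3-fold higher number from compound 3 to compound 4 (0.63 log units; beyond the scatter), though somewhat smaller, since compound 3 already starts from a weak value and measurements this weak often run into the upper edge of what the assay can report. On that basis compound 4 is estimated to give 50000 nM in this assay, with a likely range from 12000 nM to 150000 nM.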

Compound 4, half-maximal inhibitory concentration: 17800 nM
Beside the measured number, compound 4's estimate is 2.8-fold (0.45 log units) above it, within the range that was stated.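

In this assay, chloro in place of hydrogen on an aromatic carbon, applied to compound 3, gives a 1.5-fold higher number from compound 3 to compound 4 (0.19 log units; within the scatter), so this step does not carry over in size from the core of compound 1: the same change on two cores in this assay, an 11-fold higher number (1.04 log units; beyond the scatter) from compound 1 to compound 2 and a 1.5-fold higher number (0.19 log units; within the scatter) from compound 3 to compound 4, 7.1-fold (0.85 log units) apart, beyond the scatter of two such steps. Methyl in place of hydrogen on the saturated chain, applied to compound 2, gives a 1.4-fold higher number from compound 2 to compound 4 (0.13 log units; within the scatter), and this step does not carry over in size either: the same change on two cores in this assay, a 9.7-fold higher number (0.99 log units; beyond the scatter) from compound 1 to compound 3 and a 1.4-fold higher number (0.13 log units; within the scatter) from compound 2 to compound 4, 7.1-fold (0.85 log units) apart, beyond the scatter of two such steps. Each change alone thus takes compound 1 to a weaker value, yet once one change is present the other gives no step beyond the scatter; this rests on only four compounds in a single assay, and it shows neither why the two changes do not add up nor whether the same would hold on any other core.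

The compounds shown leave open whether fluoro, bromo or an amine on that aromatic carbon would behave as chloro does, and whether a longer chain would behave as the added methyl does. They also leave open what a carboxylic acid in place of the alcohol would do to either step.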